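Working notes: from compound 2 to compound 3

A few compounds are considered here, and "the series" means these few. Any claim that something is new, unique, unknown or untested is made for them only; others in the source may bear on it.

Measured so far in an ADME assay for pharmacokinetics (a higher number here means that the compound lasts longer, a lower number that the compound disappears faster), as the only read-out:
- compound 1 (`CO[C@H]1C(=O)N2C(C(=O)OCc3ccc(C(=O)O)cc3)=C(COC(C)=O)CS(=O)(=O)[C@H]12`) at (5 h)
- compound 2 (`CO[C@H]1C(=O)N2C(C(=O)N(C)CCC(=O)O)=C(COC(C)=O)CS(=O)(=O)[C@H]12`) at (24 h)

Compound 2 stands highest of these two numbers, and its gap to compound 1 lies beyond the scatter. The next compound is compound 3 (`CO[C@H]1C(=O)N2C(C(=O)N3CCCC3)=C(COC(C)=O)CS(=O)(=O)[C@H]12`), which carries pyrrolidin-1-yl in place of (2-carboxyethyl)(methyl)amino on a carbonyl carbon. Within the data shown here, no measured pair differs in one place only, so the data give no size for this change. In this assay the expected step (a 1.2-fold lower number from compound 2 to compound 3 (0.08 log units; within the scatter)) stays within the scatter, with no firm direction. For compound 3 the estimated half-life is 20 h with an expected range from 8 h to 50 h for now.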

Compound 3, half-life: 16 h
Compound 3: the middle estimate sits 1.3-fold (0.10 log units) above what was measured; low and high end bracket the measured number.
By their numbers in this assay, from the lowest: compound 1; then compounds 3 and 2 (each within the scatter of the next).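

Pyrrolidin-1-yl in place of (2-carboxyethyl)(methyl)amino on a carbonyl carbon gives the first comparison in one place in this assay, and the step, a 1.5-fold lower number from compound 2 to compound 3 (0.18 log units; within the scatter), has no firm direction. In this single pair, a chain ending in a carboxylic acid and a five-membered non-aromatic ring at this carbonyl carbon cannot be told apart. Nothing available explains this result. From the compounds shown here alone, whether a piperidine, a morpholine or a longer chain ending in a carboxylic acid at the same carbonyl carbon would also stay within the scatter remains open.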